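The source may hold more compounds than are shown below. What is called first, only, known or untested is meant among the compounds shown, and "the series" means these compounds.

Compound 1 `COc1ccc(NC(=O)[C@H]2CCCN2C(=O)C2(c3ccccc3)CCCC2)cc1` in an assay on isolated protein for inhibition of histone acetyltransferase p300 (Homo sapiens), with a stated time of 60 min; on this read-out higher numbers stand for weaker inhibition and lower numbers for stronger inhibition: 79.4 nM
Compound 2 `O=C(Nc1ccc2[nH]ccc2n1)[C@H]1CCCN1C(=O)C1(c2cccc(Cl)c2)CCCC1` in this assay: 0.159 nM

Of these two numbers, compound 2 gives the lowest; compound 1 sits far higher, a gap well beyond the usual scatter. Compound 3 `O=C(Nc1ccc2[nH]c(=O)[nH]c2c1)[C@H]1CCCN1C(=O)C1(c2cccc(Cl)c2)CCCC1` has not been measured. It differs from compound 2 in one place: a group of 10 heavy atoms (7 carbon, 2 nitrogen, 1 oxygen; one five-membered aromatic ring with 2 hetero atoms, one six-membered aromatic ring of carbon only) in place of a group of 9 heavy atoms (7 carbon, 2 nitrogen; one five-membered aromatic ring with 1 hetero atom, one six-membered aromatic ring with 1 hetero atom), on an amide-type nitrogen. Going by the values given here, no step between two measured compounds covers a change of this kind, so the expectation rests on compound 2 alone, with wide uncertainty. The change is expected to weaken inhibition somewhat, giving a step of a 19-fold higher number from compound 2 to compound 3 (1.28 log units; beyond the scatter). Compound 3 is therefore estimated at 3 nM, within a range of 0.3 nM to 30 nM.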

Compound 3, half-maximal inhibitory concentration: 0.398 nM
Beside the measured number, compound 3's estimate is 7.5-fold (0.88 log units) above it; the measured number falls inside the stated range.
By their numbers in this assay, from the lowest: compound 2; then compound 3; then compound 1.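

On the amide-type nitrogen, the group can be exchanged for a larger one with a six-membered aromatic ring of carbon only, a double bond outside the rings and one more hydrogen-bond donor at only a modest cost in this assay, with a 2.5-fold higher number from compound 2 to compound 3 (0.40 log units; beyond the scatter). A hetero atom in the six-membered ring is thus not required for a sub-nanomolar number. No measurement shown explains this step. Which part of the exchange produces the step remains open, as does how a plain phenyl group or an amine-bearing phenyl group would perform on that nitrogen.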